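The source may report more compounds than this note shows. Statements on the series, on what has been measured and on what is new or still open speak of the compounds shown alone.

Among the compounds with values here, in an ADME assay on the whole organism with Oryza sativa as the target, tested at 10 uM (on this read-out higher numbers stand for a weaker effect at the one concentration tested and lower numbers for a stronger effect), compound 2 `C[C@@H](NC(=O)Nc1ccc(C(C)(C)C)cc1)c1ccccc1` gives 53%, the lowest of the two numbers measured so far; the nearest is compound 1 `Cc1ccc(NC(=O)N[C@H](C)c2ccccc2)cc1`, which gives 64%. Within the data shown here, the only step measured between these two, a number 11 percentage points lower from compound 1 to compound 2 (beyond the scatter), came from putting tert-butyl in place of methyl on an aromatic carbon. Compound 3 `CCCCc1ccc(NC(=O)N[C@H](C)c2ccccc2)cc1` has not yet been measured; it differs from compound 2 in one place: butyl in place of tert-butyl on an aromatic carbon. Among the measured compounds shown here, no measured step bears directly on this change, since the group that leaves and the group that enters are built from the same atoms, and the one known step concerns a group with a different count of atoms. Compound 3 is therefore expected to sit close to compound 2, with an expected step of no change at the digits printed from compound 2 to compound 3 (within the scatter) that does not go beyond the scatter. The estimate for compound 3 in this assay is 53%, within a range from 40% to 66%.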

Compound 3, a percentage reported as activity, at one concentration (the size of the read-out at that concentration, not a potency): 28%
Compound 3: the middle estimate sits 25 percentage points above what was measured; measured number below the stated range.
By their numbers in this assay, from the lowest: compound 3; then compound 2; then compound 1.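

In this assay, butyl in place of tert-butyl gives a number 25 percentage points lower from compound 2 to compound 3 (beyond the scatter), even though both groups have the same atoms, so at this position the number depends on how the carbons are joined and not only on how many there are. The earlier step could not show this, since its two groups differ in their count of atoms. Butyl in place of the methyl gives a number 36 percentage points lower from compound 1 to compound 3 (beyond the scatter), and of the three groups tested on this aromatic carbon, butyl gives the lowest number, the strongest effect at the one concentration tested.

Where a longer chain such as hexyl, a shorter one such as ethyl, or a chain ending in an amine would fall on this scale remains open. No available evidence explains why butyl and tert-butyl differ.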